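Adding 1-methyl-1H-imidazol-2-yl to compound 3

A few compounds are considered here, and "the series" means these few. Any claim that something is new, unique, unknown or untested is made for them only; others in the source may bear on it.

A cell-toxicity test asks how much of a compound living cells can bear. In an ADME assay on CHO cells (Cricetulus griseus) for cytotoxicity, read by MTT assay (a lower number here means that less compound is tolerated, a higher number that more compound is tolerated), three related compounds have been tested so far. Compound 1 (`CN1CCN(C2CCN(c3nccc4[nH]c(-c5cccc(S(C)(=O)=O)c5)nc34)CC2)CC1`) gives > 50000 nM as its result, which is a limit of the assay and not a number. Compound 2 (`CN1CCN(CC2CCN(c3nccc4[nH]c(-c5cccc(C(=O)O)c5)nc34)CC2)CC1`) gives > 50000 nM as its result, which is again a limit. Compound 3 (`Fc1cc(F)cc(-c2nc3c(N4CCC(CN5CCNCC5)CC4)nccc3[nH]2)c1`) reads 20000 nM and is the only one of the three with an actual number.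

Compound 4 (`Cn1ccnc1N1CCN(CC2CCN(c3nccc4[nH]c(-c5cc(F)cc(F)c5)nc34)CC2)CC1`) has not yet been measured. It carries 1-methyl-1H-imidazol-2-yl in place of hydrogen on an amine nitrogen in a ring and piperazin-1-yl thereby becomes 4-(1-methyl-1H-imidazol-2-yl)piperazin-1-yl. Going by the values given here, no two tested compounds differ in one place only, and the data offer no direct guide to this change. The expectation starts from compound 3 at 20000 nM and stays close to it. The estimated step of a 1.3-fold lower number from compound 3 to compound 4 (0.10 log units; within the scatter) in this assay is expected to stay within the usual scatter, with a slight lean toward less compound being tolerated. For compound 4 the estimated value is 16000 nM with an expected range from 6000 nM to 45000 nM around it.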

Compound 4, half-maximal cytotoxic concentration in the CHO assay: 33000 nM
Estimate against measurement, compound 4: 2.1-fold (0.31 log units) below; the range from low to high includes it.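

Going by these compounds alone, in the CHO assay, this is the first step between two compounds that differ in one place only: a 1.7-fold higher number from compound 3 to compound 4 (0.22 log units; within the scatter). It shows that a five-membered aromatic ring can take the place of hydrogen on this amine nitrogen without a readable difference in how much compound the cells tolerate, and in a physicochemical assay for solubility, read by HPLC, using the shake flask method, in phosphate buffer, with a stated time of 20 h, at pH 6.5 (on this read-out lower numbers stand for lower solubility and higher numbers for higher solubility), the same replacement gives a 1.4-fold lower number from compound 3 to compound 4 (0.15 log units; within the scatter), so neither read-out separates the two compounds. In the physicochemical assay compound 3 gives 190000 nM and compound 4 gives 135000 nM. In the CHO assay compound 1 gives > 50000 nM, which is a limit of the assay and not a number. In the CHO assay compound 2 gives > 50000 nM, which is again a limit of the assay and not a number. Neither compound 1 nor compound 2 could show this, because each differs from compound 3 in more than one place and gives a limit of the assay rather than a number: the limit of > 50000 nM in the CHO assay, at which 2 of the 4 values shown sit.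

Going by these compounds, the pair covers a single replacement on a single core, so it remains open whether an acetyl group or a hydroxyethyl chain on the same nitrogen would also stay within the scatter. On these data alone, it is equally open whether 1-methyl-1H-imidazol-2-yl would behave the same way on a compound without the two fluorine atoms of compound 3, and a single pair cannot support a general rule for this position.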